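This account rests on a few compounds, and the source may have more. Where it says the series, first, only, none or still open, it means among the compounds named here.

Working notes on the series in a functional assay on MCF7 cells (Homo sapiens) for cytotoxicity, read by MTT assay, with a stated time of 48 h; on this read-out higher numbers stand for weaker inhibition and lower numbers for stronger inhibition.

Compound 1 `COc1cc(-c2nnc3n2NC(c2ccco2)C(C(=O)c2cccc(Br)c2)S3)cc(OC)c1OC` gives 91800 nM in this assay. Compound 2 `COc1cc(-c2nnc3n2NC(c2ccco2)C(C(=O)c2ccc(C)cc2)S3)cc(OC)c1OC` returns only the limit of this assay, > 100000 nM, and not a number. Compound 3 `COc1cc(-c2nnc3n2NC(c2ccco2)C(C(=O)c2ccc(-c4ccccc4)cc2)S3)cc(OC)c1OC` likewise returns only the limit of this assay, > 100000 nM. Among the three values shown, compound 3 therefore stands at the limit and has no number of its own; the limit of > 100000 nM in this assay, at which 2 of the 3 values shown sit, covers it and compound 2 together, while compound 1 stands close to the same mark.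

Compound 4 `COc1cc(-c2nnc3n2NC(c2ccco2)C(C(=O)c2ccc(Cl)cc2)S3)cc(OC)c1OC` differs from compound 3 by chloro in place of phenyl on an aromatic carbon. The measured steps that bear on this change are an at least 1.0-fold higher number from compound 1 to compound 3 (0.03 log units; that floor lies within the scatter), an at least 1.0-fold higher number from compound 1 to compound 2 (0.03 log units; that floor lies within the scatter), and a step that the two limits leave unreadable from compound 2 to compound 3. None of them shows a change beyond the scatter, and the one that passes between the two limit values cannot be sized at all. Going by the values given here, a chloro entering on that aromatic carbon has no measured precedent, so the expectation rests on the weak, near-flat picture given by compounds 1, 2 and 3 in this assay.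

For compound 4 a step of about an at least 1.0-fold lower number from compound 3 to compound 4 (0.02 log units; that floor lies within the scatter) is expected, that is none beyond the scatter. Compound 4 is estimated at 95000 nM, expected between 45000 nM and 100000 nM, with a real chance that this assay again returns only a limit.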

Compound 4, half-maximal inhibitory concentration: > 100000 nM
Compound 4: a limit, no number (the forecaster's own chance of this, stated with the estimate: 60%); middle value at least 1.0-fold (0.02 log units) away from the limit.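

In this assay compound 4 also returns a limit and not a number, so a third substituent at this place gives no measurable value: the limit of > 100000 nM in this assay, at which 3 of the 4 values shown sit. Chloro, methyl and phenyl, each on an aromatic carbon para to a large group, therefore leave the series without a readable ranking at this position, and the steps among compounds 2, 3 and 4 cannot be read. Going by these compounds alone, the only readable new step is an at least 1.0-fold higher number from compound 1 to compound 4 (0.03 log units; that floor lies within the scatter); it gives only a floor, so the true size of this change remains unknown.

From the compounds shown here alone, whether an amine or a carboxylic acid on the same aromatic carbon would give a number in this assay remains open. Also open, going by these compounds, is whether any change on the aryl ketone part of the shared core can produce a step beyond the scatter in this assay, as none of the readable steps shows one.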